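From cyclopropyl to methoxy on a shared core

The source may hold more compounds than are shown below. What is called first, only, known or untested is meant among the compounds shown, and "the series" means these compounds.

- compound 1 `CCc1nc(CN(C)C2CCCc3cccnc32)cc(N2CCN(C)CC2)n1`: 0.0198 h
- compound 2 `CN1CCN(c2cc(CN(C)C3CCCc4cccnc43)nc(C3CC3)n2)CC1`: 0.017 h

In an ADME assay on microsomes from liver (Rattus norvegicus) for metabolic stability, read by LC-MS, using NADPH, with stated times of 10 min and 60 min (a higher number here means that the compound lasts longer, a lower number that the compound disappears faster), compound 2 gives 0.017 h. Within the data shown here, it is the lower of only two numbers, but it lies within the scatter of compound 1 at 0.0198 h, so the two measured compounds cannot be separated.

The next structure is compound 3 `COc1nc(CN(C)C2CCCc3cccnc32)cc(N2CCN(C)CC2)n1`, which carries methoxy in place of cyclopropyl on an aromatic carbon, between two ring nitrogen atoms: methoxy in place of cyclopropyl on an aromatic carbon.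

Among the measured compounds shown here, only one measured step touches this same place, the exchange of ethyl for cyclopropyl: a 1.2-fold lower number from compound 1 to compound 2 (0.07 log units; within the scatter). For the measured compounds named here, that step stayed within the scatter, yet it offers only limited guidance, as no measured compound carries methoxy. With no evidence for a direction, no shift beyond the scatter is expected in this assay.

For compound 3 the estimated half-life is 0.02 h, with an expected range from 0.01 h to 0.045 h. The expected step is a 1.2-fold higher number from compound 2 to compound 3 (0.07 log units; within the scatter).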

Compound 3, half-life: 0.0367 h
Compound 3: middle estimate off by 1.8-fold (0.26 log units), on the low side, within the range that was stated.
By their numbers in this assay, from the lowest: compounds 2, 1 and 3 (each within the scatter of the next, the first and the last beyond it).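

In this assay, among these compounds, the position on the aromatic carbon between two ring nitrogen atoms now shows a change that can be told from the scatter: methoxy in place of cyclopropyl gives a 2.2-fold higher number from compound 2 to compound 3 (0.33 log units; beyond the scatter) and is the only step at this place that passes beyond it, though only modestly. Methoxy in place of ethyl gives a 1.9-fold higher number from compound 1 to compound 3 (0.27 log units; within the scatter) and stays within the scatter, so the separation holds against cyclopropyl alone, and compound 3 cannot be told apart from compound 1. No measurement shown here accounts for this difference between the two steps.

Going by these compounds, the series at this position holds only ethyl, cyclopropyl and methoxy, so it remains open whether an amine such as dimethylamino, a longer chain such as propyl or a longer ether such as ethoxy would extend the half-life further or fall back among the lower values. On these data alone, it is also open whether the step from cyclopropyl to methoxy would keep its size if the 4-methylpiperazin-1-yl group were exchanged for another group.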